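The source may hold more compounds than are shown below. What is called first, only, known or untested is meant among the compounds shown, and "the series" means these compounds.

Compounds measured so far:

- compound 1, `CCCCOC(=O)Nc1ccc([Se]C#N)cc1`: 12200 nM
- compound 2, `CC(C)COC(=O)Nc1ccc([Se]C#N)cc1`: 49500 nM
- compound 3, `CCCCCCOC(=O)Nc1ccc([Se]C#N)cc1`: 35900 nM

All three share one core and differ only in the alkyl group on the oxygen of the carbamate. In an ADME assay on BEAS-2B cells (Homo sapiens) for cytotoxicity, read by MTT assay, with a stated time of 72 h (a lower number here means a stronger inhibitor of growth, a higher number a weaker inhibitor of growth), compound 3 gives 35900 nM, the second highest of the three numbers; its nearest neighbour is compound 2, a 1.4-fold lower number from compound 2 to compound 3 (0.14 log units; within the scatter), while compound 1 lies further off, a 2.9-fold higher number from compound 1 to compound 3 (0.47 log units; beyond the scatter).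

Compound 4, `N#C[Se]c1ccc(NC(=O)OCc2ccccc2)cc1`, has not yet been measured. It differs from compound 3 in one place: phenyl in place of pentyl on a saturated chain carbon bound to an oxygen next to a carbonyl group. The steps seen so far were all among saturated chains and were modest or within the scatter, as in a 4.1-fold higher number from compound 1 to compound 2 (0.61 log units; beyond the scatter) and a 1.4-fold lower number from compound 2 to compound 3 (0.14 log units; within the scatter). None of them swapped a chain for a ring, so they bear on this step only loosely; they suggest that changes at this position move this assay by modest amounts. For compound 4 the expected result is therefore 25000 nM, a step of a 1.4-fold lower number from compound 3 to compound 4 (0.16 log units; within the scatter), with the estimate spanning 8000 nM to 60000 nM.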

Compound 4, concentration for total growth inhibition: 34400 nM
For compound 4 the middle estimate is 1.4-fold (0.14 log units) below the measured one; the measured number falls inside the stated range.
By their numbers in this assay, from the lowest: compound 1; then compounds 4, 3 and 2 (each within the scatter of the next).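

Placing a ring where a saturated chain stood is a new kind of change at this position, and in this assay it gives no step beyond the scatter against the pentyl version (a 1.0-fold lower number from compound 3 to compound 4 (0.02 log units; within the scatter)) or the isopropyl version (a 1.4-fold lower number from compound 2 to compound 4 (0.16 log units; within the scatter)). Only the comparison with the propyl version goes beyond the scatter (a 2.8-fold higher number from compound 1 to compound 4 (0.45 log units; beyond the scatter)), so compound 1 remains apart from the other three compounds, now including one with a phenyl group. Nothing available explains why the phenyl group and these two chains read alike, or why compound 1 differs.

Still open, going by these compounds, is whether a group carrying an amine or a carboxylic acid at this position would stay with compounds 2, 3 and 4 or move away from them. A chlorine atom on the phenyl ring, or a chain longer than that of compound 3, is equally untested by these compounds.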